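A few compounds are considered here, and "the series" means these few. Any claim that something is new, unique, unknown or untested is made for them only; others in the source may bear on it.

Measured in a functional assay on KG-1 cells (Homo sapiens) for cytotoxicity, read by luminescence and CellTiter-Glo, with a stated time of 3 days; a higher number here means a weaker inhibitor, a lower number a stronger inhibitor:
compound 1, `N#Cc1ccc(NC(=O)c2ccc(-c3cccnc3)cc2O)cc1`: 7940 nM
compound 3, `N#Cc1ccc(NC(=O)c2ccc3cccnc3c2O)c(C#N)c1`: 3770 nM
compound 2, `COc1ccc(O)c(C(=O)Nc2ccc(C#N)cc2)c1`: > 10000 nM

The value of compound 2 is a limit of the assay, not a number: compound 2 sits at the limit of > 10000 nM in this assay, at which 1 of the 3 values shown sits, and so its true potency is known only to be weaker than the other two compounds measured.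

Compound 4, `N#Cc1ccc(NC(=O)c2ccccc2O)cc1`, differs from compound 2 by hydrogen in place of methoxy on an aromatic carbon. Within the data shown here, since compound 2 itself gives no number, no measured step shows what this change does. The smaller compound 4 is expected to stay about where compound 2 stands, with little or no step beyond the scatter, as it also lacks the pyridyl and fused ring present in compound 1 and compound 3.

Compound 4 is therefore expected to give 12000 nM, between 5000 nM and 30000 nM, a step that the limit leaves unreadable from compound 2 to compound 4, and may well again return only a limit.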

Compound 4, half-maximal inhibitory concentration: 5370 nM
Compound 4: the middle estimate sits 2.2-fold (0.35 log units) above what was measured, and the stated range covers the measured number.
By their numbers in this assay, from the lowest: compounds 3, 4 and 1 (each within the scatter of the next, the first and the last beyond it). At a limit, above all of these: compound 2.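

In this assay, hydrogen in place of methoxy, on the aromatic carbon para to a hydroxy group, gives an at least 1.8-fold lower number from compound 2 to compound 4 (0.27 log units; that floor lies within the scatter). From the compounds shown here alone, its true size stays unknown, since compound 2 is a limit and not a number: the limit of > 10000 nM in this assay, at which 1 of the 4 values shown sits. Hydrogen in place of pyridin-3-yl gives a 1.5-fold lower number from compound 1 to compound 4 (0.17 log units; within the scatter), so this change shows no step beyond the scatter.

The compounds shown leave open how far the methoxy step really reaches. They also leave open what an amine or a carboxylic acid on that aromatic carbon would do.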